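The source may report more compounds than this note shows. Statements on the series, on what has been measured and on what is new or still open speak of the compounds shown alone.

Of the compounds shown here, three have so far been tested in a functional assay on the whole organism with Mus musculus as the target, in the maximal electroshock model, at a dose of 50 mg/kg by the oral route; on this read-out higher numbers stand for more inhibition at the one dose given (going by the name of the read-out) and lower numbers for less inhibition. Compound 1 `C(=C/c1ccccc1OCCCCN1CCCCC1)\c1ccccc1` gives 42.9% in this assay, the highest of the three numbers. Compound 2 `CN(C)CCCCOc1ccc(/C=C/c2ccccc2)cc1` gives 12.5%, a number that falls well short of compound 1 and beyond the usual scatter, and compound 3 `CN1CCN(CCCCOc2ccccc2/C=C/c2ccc(Cl)c(Cl)c2)CC1` gives 0%, still further below. Compound 4 `OCC1CCCN(CCCCOc2ccccc2/C=C/c2ccccc2)C1` has not yet been measured. It differs from compound 1 by hydroxymethyl in place of hydrogen on a saturated ring carbon. Going by the values given here, no measured pair shows what this kind of change does in this assay, so only a modest step is expected, a number 7.9 percentage points lower from compound 1 to compound 4 (within the scatter), with no direction clearly beyond the scatter. Compound 4 is therefore estimated to give 35%, with a likely range from 10% to 65%.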

Compound 4, a percentage reported as inhibition, in the whole organism at one dose (the size of the read-out at that dose, not a potency): 12.5%
Estimate against measurement, compound 4: 22.5 percentage points above; the measured number falls inside the stated range.
By their numbers in this assay, from the lowest: compound 3; then compounds 2 and 4 (each within the scatter of the next); then compound 1.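

Going by these compounds alone, this is the first pair of compounds that differ in one place, and it shows that the ring carrying the nitrogen is not indifferent to substitution. In this assay, hydroxymethyl in place of hydrogen, on a saturated ring carbon two ring bonds from the ring nitrogen, brings a number 30.4 percentage points lower from compound 1 to compound 4 (beyond the scatter). Nothing available explains this fall. Still open, from the compounds shown here alone, is whether a methyl group or an aminomethyl group on the same ring carbon would bring a step of similar size, which would help show whether the oxygen of hydroxymethyl matters.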